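This account rests on a few compounds, and the source may have more. Where it says the series, first, only, none or still open, it means among the compounds named here.

Compound 1 `CC(=O)N1CCN(S(=O)(=O)c2ccc(F)cc2)CC1CO` carries a hydrogen on the oxygen on the saturated carbon. In a physicochemical assay for metabolic stability, read by LC-MS, in phosphate buffer, tested at 1 uM (on this read-out higher numbers stand for a longer-lived compound and lower numbers for a shorter-lived compound), compound 1 gives >= 4 h, which is a limit of the assay rather than a number. Compound 2 `CC(=O)OCC1CN(S(=O)(=O)c2ccc(F)cc2)CCN1C(C)=O` carries the acetyl on that oxygen. In this assay compound 2 gives >= 4 h, again a limit of the assay and not a number. The step from compound 1 to compound 2 is a step that the two limits leave unreadable from compound 1 to compound 2. Compound 2 therefore stands at the limit of >= 4 h in this assay, at which 2 of the 2 values shown sit, with no number of its own.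

Compound 3 `COCC1CN(S(=O)(=O)c2ccc(F)cc2)CCN1C(C)=O` has yet to be measured. It differs from compound 2 in one place: methyl in place of acetyl on an oxygen on a saturated carbon. For the measured compounds named here, only the step from compound 1 to compound 2 touches this oxygen, and that step, a step that the two limits leave unreadable from compound 1 to compound 2, has no readable size. Going by the values given here, no measured step thus fixes what the acetyl-to-methyl exchange should do in this assay. With both measured neighbours at the limit, the expectation for compound 3 in this assay is a step of a number no higher from compound 2 to compound 3 (the limit leaves the size open), that is none beyond the scatter, most likely ending at the limit again. Compound 3 is accordingly estimated at 4 h, with a range from 2.5 h to 8 h.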

Compound 3, half-life: >= 4 h
Compound 3 gave a limit, no number; the forecaster's own chance of this, stated with the estimate: 75%; the middle value lies on the limit itself.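

No new step can be read among compound 1, compound 2 and compound 3 in this assay, since all three give a limit of the assay and not a number: the limit of >= 4 h in this assay, at which 3 of the 3 values shown sit.

The compounds shown leave open how long each one actually lasts, and so whether hydrogen, acetyl and methyl on this oxygen differ at all in this read-out.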